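A few compounds are considered here, and "the series" means these few. Any claim that something is new, unique, unknown or untested is made for them only; others in the source may bear on it.

- compound 1 `CNC(=O)c1cccc(-c2ccc(NC(=O)Nc3ccc(Cl)c(C(F)(F)F)c3)cc2)c1` with 29300 nM
- compound 2 `O=C(CCc1ccc(NC(=O)Nc2ccc(Cl)c(C(F)(F)F)c2)cc1)NC1CCC1` with 21300 nM

In a functional assay on HT-29 cells (Homo sapiens) for inhibition, read by MTT assay, with a stated time of 120 h (a lower number here means a stronger inhibitor, a higher number a weaker inhibitor), compound 2 lies within the scatter of compound 1, so neither stands apart. Compound 3 `CNC(=O)C#Cc1ccc(NC(=O)Nc2ccc(Cl)c(C(F)(F)F)c2)cc1` carries 2-(methylcarbamoyl)ethynyl in place of 2-(cyclobutylcarbamoyl)ethyl on an aromatic carbon. For the measured compounds named here, the one measured step at this place is a 1.4-fold lower number from compound 1 to compound 2 (0.14 log units; within the scatter), and no measured compound yet holds the incoming group. On that single step, no change beyond the scatter is expected in this assay. The expected step is a 1.1-fold lower number from compound 2 to compound 3 (0.03 log units; within the scatter) and no more. For compound 3 the estimated value is 20000 nM, within an estimated range of 7000 nM to 50000 nM.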

Compound 3, half-maximal inhibitory concentration: 14000 nM
Compound 3: the middle estimate sits 1.4-fold (0.15 log units) above what was measured, and the stated range covers the measured number.
By their numbers in this assay, from the lowest: compounds 3, 2 and 1 (each within the scatter of the next, the first and the last beyond it).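

In this assay, 2-(methylcarbamoyl)ethynyl, which has no ring, stands level with 2-(cyclobutylcarbamoyl)ethyl (a 1.5-fold lower number from compound 2 to compound 3 (0.18 log units; within the scatter)), so the four-membered ring is not required at this position to keep the number in this range. For the compounds shown here, replacing 3-(methylcarbamoyl)phenyl with the same group gives the first step at this position beyond the scatter, though a modest one (a 2.1-fold lower number from compound 1 to compound 3 (0.32 log units; beyond the scatter)). Nothing available explains either step. All three groups at this position carry a carbamoyl unit. As far as these compounds go, whether a carboxylic acid or an amine could stand in its place remains open.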